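Aryl change at the ring carbon: compound 3 to compound 4

The source may hold more compounds than are shown below. What is called first, only, known or untested is meant among the compounds shown, and "the series" means these compounds.

In a functional assay on A549 cells (Homo sapiens) for cytotoxicity, read by MTT assay, with a stated time of 48 h (on this read-out lower numbers stand for stronger inhibition and higher numbers for weaker inhibition), compound 1 (`COc1ccc(OC)c(C2=NOC(COc3ccc(-c4nnnn4-c4cc(OC)c(OC)c(OC)c4)cc3N)C2)c1`) gives 1930 nM, compound 2 (`COc1cc(C2=NOC(COc3ccc(-c4nnnn4-c4cc(OC)c(OC)c(OC)c4)cc3N)C2)cc(OC)c1OC`) gives 2060 nM and compound 3 (`COc1cc(-n2nnnc2-c2ccc(OCC3CC(c4ccc(C(F)(F)F)cc4)=NO3)c(N)c2)cc(OC)c1OC`) gives 1220 nM. Compound 3 therefore stands level with the other two, as the steps show: a 1.6-fold lower number from compound 1 to compound 3 (0.20 log units; within the scatter) and a 1.7-fold lower number from compound 2 to compound 3 (0.23 log units; within the scatter).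

Compound 4 (`COc1cc(-n2nnnc2-c2ccc(OCC3CC(c4cccc(Cl)c4)=NO3)c(N)c2)cc(OC)c1OC`) has 3-chlorophenyl in place of 4-(trifluoromethyl)phenyl on a carbon with a double bond to nitrogen. The rest of the structure is unchanged.

All three measured steps bear on this change, since each swaps the aryl group at the same place. Besides the two steps to compound 3, the third is a 1.1-fold higher number from compound 1 to compound 2 (0.03 log units; within the scatter). None of them leaves the scatter, although the outgoing and incoming groups differ in each case. Within the data shown here, no measured compound carries 3-chlorophenyl, so the data offer no direct reading for this group. No step beyond the scatter is therefore expected in this assay.

The expected step is a 1.2-fold higher number from compound 3 to compound 4 (0.09 log units; within the scatter). For compound 4 the estimated value is 1500 nM. The estimated range for compound 4 runs from 800 nM to 2800 nM.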

Compound 4, half-maximal inhibitory concentration: 1340 nM
Estimate against measurement, compound 4: 1.1-fold (0.05 log units) above, within the range that was stated.
By their numbers in this assay, from the lowest: compounds 3, 4, 1 and 2 (each within the scatter of the next).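

In this assay, 3-chlorophenyl on the carbon with a double bond to nitrogen stays within the scatter of each aryl group seen there before (a 1.1-fold higher number from compound 3 to compound 4 (0.04 log units; within the scatter); a 1.5-fold lower number from compound 2 to compound 4 (0.19 log units; within the scatter); a 1.4-fold lower number from compound 1 to compound 4 (0.16 log units; within the scatter)). This extends the earlier picture to a chlorine-bearing ring, and one that is smaller by heavy-atom count than the 4-(trifluoromethyl)phenyl it replaces, so methoxy-bearing, trifluoromethyl-bearing and chlorine-bearing aryl groups now all sit level at this position, and none of the four compounds goes against that. No supporting evidence is available to explain why this position shows so little response to the aryl change.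

As far as these compounds go, all four compounds carry a phenyl ring at this carbon, so it remains open whether a group of another kind there, such as a carboxylic acid, an amine or a longer alkyl chain, would give a step beyond the scatter. From the compounds shown here alone, with the rest of the structure held constant throughout, it is also open whether the shared core responds more strongly to change elsewhere, for example on replacing the amine that all four compounds carry with a nitrile.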